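Swapping 4-nitrophenyl for 2,3-dichlorophenyl

The source may report more compounds than this note shows. Statements on the series, on what has been measured and on what is new or still open speak of the compounds shown alone.

In a functional assay on A549 cells (Homo sapiens) for antiproliferative activity, read by MTT assay, with a stated time of 72 h (a higher number here means a weaker inhibitor, a lower number a stronger inhibitor), compound 1 `N#Cc1ccc(/C=N/NC(=O)Nc2ccc(Oc3ccnc4[nH]ccc34)c(F)c2)cc1` gives 1360 nM and compound 2 `O=C(N/N=C/c1ccc([N+](=O)[O-])cc1)Nc1ccc(Oc2ccnc3[nH]ccc23)c(F)c1` gives 20 nM. Compound 2 thus holds the lower of the two numbers and is the stronger inhibitor of the pair. The next structure, compound 3 `O=C(N/N=C/c1cccc(Cl)c1Cl)Nc1ccc(Oc2ccnc3[nH]ccc23)c(F)c1`, keeps the shared core and changes one group: 2,3-dichlorophenyl in place of 4-nitrophenyl on a carbon with a double bond to nitrogen. In words, 2,3-dichlorophenyl stands in place of 4-nitrophenyl on a carbon with a double bond to nitrogen.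

Within the data shown here, one measured step bears on this: a 68-fold lower number from compound 1 to compound 2 (1.83 log units; beyond the scatter), with nitro in place of cyano on an aromatic carbon. Among the measured compounds shown here, it shows that a single group on this aromatic ring can move the number strongly, but it rests on one pair, and no compound with chlorine has been measured. For the measured compounds named here, the only other group measured, in compound 1, gives 1360 nM, so a moderate to large rise in this assay is expected rather than a further fall. The expected step is a 7.5-fold higher number from compound 2 to compound 3 (0.88 log units; beyond the scatter). For compound 3 the estimated value is 150 nM, with an expected range of 25 nM to 1200 nM.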

Compound 3, half-maximal inhibitory concentration: "not active" (no number reported)
Compound 3: no number reported; there is nothing to compare the estimate with.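

In this assay, among these compounds, compound 3 is reported as "not active" without a number, so no step from compound 2 to compound 3 can be read. No other data on hand bear on this result. The compounds shown leave open how large the gap between 2,3-dichlorophenyl and 4-nitrophenyl actually is.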